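This account rests on a few compounds, and the source may have more. Where it says the series, first, only, none or still open, it means among the compounds named here.

Working notes on the series. Three members have been taken through an ADME assay on MDBK cells (Bos taurus) for cytotoxicity, read by MTT assay (a lower number here means that less compound is tolerated, a higher number that more compound is tolerated), so far: compound 1 `OC[C@@H]1[C@@H](O)[C@H](O)[C@@H](O)CN1CCCCCCN(C1CCCCC1)C1CCCCC1`, compound 2 `CC(C)(C)C(=O)N(CCCCCCN1C[C@H](O)[C@@H](O)[C@H](O)[C@H]1CO)C1CCCCC1` and compound 3 `CC(=O)N(CCCCCCN1C[C@H](O)[C@@H](O)[C@H](O)[C@H]1CO)C1CCCCC1`, all sharing the same core and the hexamethylene linker. In this assay compound 1 gives > 500000 nM, which is a limit of the assay and not a number. Compound 2 gives > 500000 nM, also a limit. Compound 3 gives > 500000 nM, again a limit. Within the data shown here, compound 3 therefore stands at the limit of > 500000 nM in this assay, at which 3 of the 3 values shown sit, and none of the measured steps can be sized: a step that the two limits leave unreadable from compound 1 to compound 2, a step that the two limits leave unreadable from compound 1 to compound 3 and a step that the two limits leave unreadable from compound 2 to compound 3 are all unreadable between two limits.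

The next member, compound 4 `CC(C)(C)CC(=O)N(CCCCCCN1C[C@H](O)[C@@H](O)[C@H](O)[C@H]1CO)C1CCCCC1`, differs from compound 3 by tert-butyl in place of hydrogen on a saturated chain carbon bound to a carbonyl carbon. The nearest comparison is the acyl growth from compound 2 to compound 3, which gave nothing readable. On that basis the step that the limit leaves unreadable from compound 3 to compound 4 is expected to stay beyond the scatter in neither direction. Compound 4 is expected at 600000 nM, within 250000 nM to 2000000 nM, most likely reported again as a limit.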

Compound 4, half-maximal cytotoxic concentration: > 500000 nM
Compound 4 gave a limit, no number; the forecaster's own chance of this, stated with the estimate: 80%; the middle value does not contradict the limit.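

In this assay, among these compounds, compound 4 gives > 500000 nM, a limit of the assay and not a number, so no step linking it to compound 1, compound 2 or compound 3 can be read: the limit of > 500000 nM in this assay, at which 4 of the 4 values shown sit. The compounds shown leave open what size any of these changes has in this assay, as none of them gives a number.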